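From 2-fluorophenyl to 4-fluorophenyl on the shared core

This account rests on a few compounds, and the source may have more. Where it says the series, first, only, none or still open, it means among the compounds named here.

In an ADME assay on microsomes from liver (Mus musculus) for metabolic stability, read by LC-MS, with a stated time of 1 h, tested at 5 uM (on this read-out lower numbers stand for a less stable compound and higher numbers for a more stable compound), compound 2 `Cc1nc(-c2ccccc2F)c(C(=O)N2CCN(c3cc(Cl)cc(Cl)c3)CC2)o1` gives 49%. Compound 1 `Cc1ccc(C)c(N2CCN(C(=O)c3oc(C)nc3-c3ccccc3)CC2)c1` gives 1.4%. Within the data shown here, compound 2 holds the higher of the two numbers so far, and the gap between the two compounds lies beyond the scatter. These two differ in more than one place, so their gap does not isolate any single change. Next, compound 3 `Cc1nc(-c2ccc(F)cc2)c(C(=O)N2CCN(c3cc(Cl)cc(Cl)c3)CC2)o1` carries 4-fluorophenyl in place of 2-fluorophenyl on an aromatic carbon. Among the measured compounds shown here, no measured pair covers this change, so no step beyond the scatter is expected in this assay. The expected step is a number 4 percentage points lower from compound 2 to compound 3 (within the scatter). For compound 3 the estimate is 45%, with an expected range of 22% to 68%.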

Compound 3, percent of the compound remaining: 31.1%
Compound 3: middle estimate off by 13.9 percentage points, on the high side; measured number inside the range.
By their numbers in this assay, from the lowest: compound 1; then compound 3; then compound 2.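

In this assay, 4-fluorophenyl in place of 2-fluorophenyl on this aromatic carbon, next to the ring nitrogen, gives a number 17.9 percentage points lower from compound 2 to compound 3 (beyond the scatter) on the shared core. Among these compounds, this is the first step that isolates a single change, and the two groups have the same atoms, joined differently. Nothing at hand accounts for the step.

Still open, on these data alone, is how a nitrile or a methoxy group in place of the fluorine would read at this position. As far as these compounds go, whether the step holds on another core also remains open.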